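The source may report more compounds than this note shows. Statements on the series, on what has been measured and on what is new or still open speak of the compounds shown alone.

Measured so far:
Compound 1, `CN(CC1CC1)CC1(O)CCN(CCCc2c[nH]c3ccc(-n4cnnc4)cc23)CC1`: 1.35 nM
Compound 2, `Cc1ccccc1CN(C)CC1(O)CCN(CCCc2c[nH]c3ccc(-n4cnnc4)cc23)CC1`: 1.3 nM
Compound 3, `CC(C)(C)OC(=O)NCC1(O)CCN(CCCc2c[nH]c3ccc(-n4cnnc4)cc23)CC1`: 21 nM

These three share one core and differ only in the group on the saturated chain carbon bound to a saturated ring carbon. In an assay on CHO cells with 5-hydroxytryptamine receptor 1D (Homo sapiens) as the target (a higher number here means a weaker inhibitor, a lower number a stronger inhibitor), compound 3 gives the highest number of the three: the step of a 16-fold higher number from compound 1 to compound 3 (1.19 log units; beyond the scatter) and the step of a 16-fold higher number from compound 2 to compound 3 (1.21 log units; beyond the scatter) both go far beyond the scatter, while the step of a 1.0-fold lower number from compound 1 to compound 2 (0.02 log units; within the scatter) does not. Compound 4, `CN(Cc1ccccc1)CC1(O)CCN(CCCc2c[nH]c3ccc(-n4cnnc4)cc23)CC1`, has not yet been measured. It differs from compound 3 in one place: benzyl(methyl)amino in place of (tert-butoxycarbonyl)amino on a saturated chain carbon bound to a saturated ring carbon. This change runs back in the direction of compounds 1 and 2, both of which carry a tertiary amine at this position, and compound 4 is the closest cousin of compound 2 among them. Because the step of a 16-fold higher number from compound 2 to compound 3 (1.21 log units; beyond the scatter) was large, a step of about the same size in the opposite direction is expected here, a 15-fold lower number from compound 3 to compound 4 (1.18 log units; beyond the scatter). For compound 4 in this assay the estimate is therefore 1.4 nM, with a range from 0.6 nM to 3.5 nM.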

Compound 4, half-maximal inhibitory concentration: 1.2 nM
Compound 4: the middle estimate sits 1.2-fold (0.07 log units) above what was measured, and the stated range covers the measured number.
By their numbers in this assay, from the lowest: compounds 4, 2 and 1 (each within the scatter of the next); then compound 3.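

In this assay, putting benzyl(methyl)amino in place of (tert-butoxycarbonyl)amino gives an 18-fold lower number from compound 3 to compound 4 (1.24 log units; beyond the scatter), so a third tertiary amine at this position also stands well apart from compound 3. The methyl on the aromatic ring makes no clear difference, with a 1.1-fold lower number from compound 2 to compound 4 (0.03 log units; within the scatter), and neither does the choice of phenyl or cyclopropyl, with a 1.1-fold lower number from compound 1 to compound 4 (0.05 log units; within the scatter), so among compounds 1, 2 and 4 these changes leave the number within the scatter, while compound 3 alone stands apart. Nothing measured here explains why the (tert-butoxycarbonyl)amino group differs from these tertiary amines.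

The compounds shown leave open whether a primary amine or an acetamide at this position would group with the tertiary amines or with compound 3. They also leave open whether a longer chain between the amine nitrogen and the phenyl would keep the number this low.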